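A few compounds are considered here, and "the series" means these few. Any claim that something is new, unique, unknown or untested is made for them only; others in the source may bear on it.

Among the measured compounds shown here, in a functional assay on SMOV2 cells (Homo sapiens) for antiproliferative activity, read by sulforhodamine B assay, with a stated time of 3 days (on this read-out higher numbers stand for weaker inhibition of growth and lower numbers for stronger inhibition of growth), compound 2 `CCc1cc(F)ccc1-c1nc(-c2ccc3[nH]c(=O)oc3c2)cs1` gives 13 nM, the lower of the two actual numbers measured so far. Compound 1 `O=c1[nH]c2ccc(-c3csc(-c4ccc(F)c(O)c4)n3)cc2o1` gives 1600 nM, a gap well beyond the scatter. Compound 3 `Cc1cc(F)ccc1-c1nc(-c2ccc3c(c2)[nH]c(=O)n3CCN(C)C)cs1` reports only a limit, > 50000 nM. Compound 4 `NCCOCc1cc(F)ccc1-c1nc(-c2ccc3[nH]c(=O)oc3c2)cs1` differs from compound 2 in one place: 2-aminoethoxy in place of methyl on a saturated chain carbon bound to an aromatic carbon. For the measured compounds named here, no measured pair shows a change of this kind, so the expectation is loose. In this assay the expected change is a 12-fold higher number from compound 2 to compound 4 (1.06 log units; beyond the scatter), a moderate move beyond the scatter toward weaker inhibition of growth. The estimate for compound 4 is 150 nM, with an expected range of 30 nM to 1000 nM.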

Compound 4, concentration for 50% growth inhibition: 3 nM
Compound 4: middle estimate off by 50-fold (1.70 log units), on the high side, outside the stated range (below it).
By their numbers in this assay, from the lowest: compound 4; then compound 2; then compound 1. At a limit, above all of these: compound 3.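

In this assay, the saturated chain carbon bound to an aromatic carbon accepts a larger group without any loss of growth inhibition: putting 2-aminoethoxy in place of methyl gives a 4.3-fold lower number from compound 2 to compound 4 (0.64 log units; beyond the scatter). Among the compounds shown here, the earlier compounds showed no change at this place, so this is the first sign that a chain carrying an oxygen and an amine is accepted here, with a modest gain. Nothing measured here explains that gain. Going by these compounds, it remains open whether the amine matters, or whether a chain ending in a hydroxyl or methoxy group would do as well. A longer chain is equally untested among the compounds shown.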